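Cyclopropylsulfonyl for cyclopentylcarbonyl on the shared core

The source may hold more compounds than are shown below. What is called first, only, known or untested is meant among the compounds shown, and "the series" means these compounds.

Compound 1 `O=C(C1CC12CCC2)N1CCc2nc(C#Cc3ccccc3)sc2C1`: in an assay on HEK293 cells for negative allosteric modulation of metabotropic glutamate receptor 5 (Homo sapiens), read by FLIPR, with a stated time of 1 h (a higher number here means a weaker inhibitor, a lower number a stronger inhibitor), compound 1 gives > 10000 nM, which is a limit of the assay and not a number.
Compound 2 `O=C(C1CCCC1)N1CCc2nc(C#Cc3ccccc3)sc2C1`: in this assay compound 2 gives > 10000 nM, likewise a limit.

Within the data shown here, the single measured step, a step that the two limits leave unreadable from compound 1 to compound 2, cannot be sized, since both ends are limits; the limit of > 10000 nM in this assay, at which 2 of the 2 values shown sit, holds both values shown. Compound 2 therefore stands only at that limit, with no number of its own, and nothing places it above or below compound 1.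

Compound 3 `O=S(=O)(C1CC1)N1CCc2nc(C#Cc3ccccc3)sc2C1` differs from compound 2 by cyclopropylsulfonyl in place of cyclopentylcarbonyl on an amine nitrogen in a ring. Among the measured compounds shown here, no measured step bears on this change: the only step available exchanges one carbonyl-bearing ring for another and is itself unreadable. No basis exists for expecting a gain in this assay beyond the scatter, and the two limits give no basis for a loss either. Compound 3 is therefore expected to sit near the limit again, with a step that the limit leaves unreadable from compound 2 to compound 3 estimated from compound 2. The estimate for compound 3 in this assay is 15000 nM, within 3000 nM to 60000 nM, most likely reported only as a limit.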

Compound 3, half-maximal inhibitory concentration: 34 nM
Compound 3: middle estimate off by 440-fold (2.64 log units), on the high side; the whole stated range lies above it.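

Notes on the amine nitrogen in a ring: in this assay, this position can carry a substituent that gives a measured value, and cyclopropylsulfonyl in place of cyclopentylcarbonyl produces an at least 290-fold lower number from compound 2 to compound 3 (2.46 log units; beyond the scatter). The comparison with the other carbonyl compound gives an at least 290-fold lower number from compound 1 to compound 3 (2.46 log units; beyond the scatter), so the large step is not confined to the cyclopentylcarbonyl comparison, and both sizes are bounds set by a limit rather than measured gaps. Compound 1 and compound 2 each remain at a limit of the assay, not a number, and the step between them cannot be read: the limit of > 10000 nM in this assay, at which 2 of the 3 values shown sit.

Still open, from the compounds shown here alone, is whether the large step belongs to the sulfonyl in place of the carbonyl, to the three-membered ring in place of the five-membered one, or only to the two together, as both change in the same step. Cyclopropylcarbonyl and cyclopentylsulfonyl on the same nitrogen would separate these two parts, and a methylsulfonyl group or a longer chain on the sulfonyl would show how much the cyclopropyl ring itself matters there.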